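Methylsulfonylphenyl Analogue Expected to Stay Below Cytotoxic Range

The source may hold more compounds than are shown below. What is called first, only, known or untested is meant among the compounds shown, and "the series" means these compounds.

Compound 3 `CC(C)N(Cc1cccc(OCCCCCC(=O)O)c1)C(=O)c1ccc(-c2ccc3c(c2)OCCO3)cc1` is one of three close relatives examined in an ADME assay on BJ cells (Homo sapiens) for cytotoxicity, read by CellTiter-Glo and resazurin assay, with a stated time of 72 h; on this read-out higher numbers stand for an effect only at larger amounts of compound and lower numbers for an effect already at smaller amounts. In this assay compound 3 gives only a limit, > 21900 nM. Compound 1 `CC(C)N(Cc1cccc(OCCCCCC(=O)O)c1)C(=O)c1ccc(-c2cccc(N(C)C)c2)cc1` likewise reaches only a limit in this assay, > 26000 nM. Compound 2 `CC(C)N(Cc1cccc(OCCCCCC(=O)O)c1)C(=O)c1ccc(-c2cccc(-c3ccccc3)c2)cc1` also stops at a limit in this assay, > 26000 nM. Compound 3 therefore stands at the limit of > 21900 nM in this assay, at which 1 of the 3 values shown sits, while the two others sit at the limit of > 26000 nM in this assay, at which 2 of the 3 values shown sit. None of the steps among them can be read: the step that the two limits leave unreadable from compound 1 to compound 3 and the step that the two limits leave unreadable from compound 2 to compound 3 both end at compound 3, and the step that the two limits leave unreadable from compound 1 to compound 2 is equally unreadable.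

Compound 4 `CC(C)N(Cc1cccc(OCCCCCC(=O)O)c1)C(=O)c1ccc(-c2cccc(S(C)(=O)=O)c2)cc1` is the next member. The change from compound 3 is 3-(methylsulfonyl)phenyl in place of 2,3-dihydro-1,4-benzodioxin-6-yl on an aromatic carbon. The two steps that bear on this change, a step that the two limits leave unreadable from compound 1 to compound 3 and a step that the two limits leave unreadable from compound 2 to compound 3, are unreadable, so no step beyond the scatter can be anticipated. In this assay compound 4 is expected to remain at the limit, and the step that the limit leaves unreadable from compound 3 to compound 4 is estimated as essentially none. The estimate for compound 4 in this assay is 26000 nM, with an expected range from 13000 nM to 52000 nM.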

Compound 4, half-maximal effective concentration: > 26000 nM
Compound 4 gave a limit, no number; the forecaster's own chance of this, stated with the estimate: 85%; the middle value lies on the limit itself.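

Compound 4 also stops at a limit in this assay, and none of its steps from compound 1, compound 2 or compound 3 can be read. The compounds shown leave open at what concentration, if any, these four compounds would reach a half-maximal effect in this assay, and whether the groups exchanged among them differ there at all.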